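Notes on swapping the spiro amine for cyclobutylmethoxy

The source may report more compounds than this note shows. Statements on the series, on what has been measured and on what is new or still open speak of the compounds shown alone.

Measured in a physicochemical assay for lipophilicity, at pH 7.4; a lower number here means a more polar compound, a higher number a more lipophilic compound:
- compound 1 `Cc1cc(COc2cccc(F)c2)nc(-c2ccccn2)n1`: 3.1
- compound 2 `CC(C)Nc1cc(COc2cccc(F)c2)nc(-c2ccccn2)n1`: 4.3
- compound 3 `Fc1ccc(OCc2cc(N3CC4(CCO4)C3)nc(-c3ccccn3)n2)c(F)c1F`: 3.3

Compound 3 at 3.3 cannot be told apart from compound 1 at 3.1. Compound 2 at 4.3 lies beyond the scatter from both of them, on the higher side.

The next compound to be measured is compound 4 `Fc1ccc(OCc2cc(OCC3CCC3)nc(-c3ccccn3)n2)c(F)c1F`. The structural change from compound 3 is a group of 6 heavy atoms (5 carbon, 1 oxygen; one four-membered non-aromatic ring of carbon only) in place of a group of 7 heavy atoms (5 carbon, 1 nitrogen, 1 oxygen; 2 four-membered non-aromatic rings with 1 hetero atom each), on an aromatic carbon. The entering group is cyclobutylmethoxy, and it sits next to the ring nitrogen, meta to a pyridin-2-yl group.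

Within the data shown here, no measured step makes this exact exchange. Among the measured compounds shown here, the only measured step at an aromatic carbon is a number 1.20 log units higher from compound 1 to compound 2 (beyond the scatter), with isopropylamino in place of methyl, which is large and beyond the scatter. For the measured compounds named here, compounds 2 and 3 differ in more than one place, so their gap gives no clean step. Going by the values given here, with only that one step as a guide, a large change in this assay is plausible here, and the direction is taken as upward, since a ring of carbon only replaces rings with a hetero atom each. The expected step, of similar size to the measured one, is a number 1.10 log units higher from compound 3 to compound 4 (beyond the scatter). For compound 4 the estimated value is 4.4, within an expected range of 3.9 to 4.9.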

Compound 4, distribution coefficient: 4.5
The estimate for compound 4 lay 0.10 log units below the measured number, and the stated range covers the measured number.
By their numbers in this assay, from the lowest: compounds 1 and 3 (each within the scatter of the next); then compounds 2 and 4 (each within the scatter of the next).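

In this assay, the exchange of the spiro amine for cyclobutylmethoxy on the aromatic carbon next to the ring nitrogen now has a direct reading: a number 1.20 log units higher from compound 3 to compound 4 (beyond the scatter). Set beside a number 1.20 log units higher from compound 1 to compound 2 (beyond the scatter), this gives two large steps at an aromatic carbon, so the size of change possible at such a carbon no longer rests on a single pair, although the two steps involve different leaving and entering groups and the two pairs carry different substitution on the benzyl ether side. Neither group in the new step has a hydrogen-bond donor or a net charge, and no supporting measurement is available to explain the step.

The exchange alters the linking atom and the ring together, so the compounds shown cannot assign the step to either change; a cyclobutylmethylamino group at this carbon would separate the two. On these data alone, whether the same step would appear on the core of compound 1 also stays open, as does the outcome with a longer open chain such as n-pentyloxy in place of cyclobutylmethoxy.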